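From cyclopropyl to 4-chlorophenyl on the shared core

A few compounds are considered here, and "the series" means these few. Any claim that something is new, unique, unknown or untested is made for them only; others in the source may bear on it.

For the measured compounds named here, in a functional assay on HCT-116 cells (Homo sapiens) for antiproliferative activity, read by MTT assay, with a stated time of 72 h (a lower number here means a stronger inhibitor, a higher number a weaker inhibitor), compound 2 `COc1ncc(-c2ccc3c(c2)N(C2CC2)C(=O)CO3)cc1NS(=O)(=O)c1ccc(F)cc1` gives 24300 nM, the only actual number so far. For compound 1 `COc1cccc(N2C(=O)COc3ccc(-c4cnc(OC)c(NS(=O)(=O)c5ccc(F)cc5)c4)cc32)c1`, the assay reports only a limit, > 40000 nM. Going by the values given here, the one measured step, with cyclopropyl in place of 3-methoxyphenyl, is an at least 1.6-fold lower number from compound 1 to compound 2 (0.21 log units; that floor lies within the scatter). Compound 3 `COc1ncc(-c2ccc3c(c2)N(c2ccc(Cl)cc2)C(=O)CO3)cc1NS(=O)(=O)c1ccc(F)cc1` carries a different change: 4-chlorophenyl in place of cyclopropyl on an amide-type nitrogen in a ring. Only the measured step from compound 1 bears on this, and it gives no firm size. The expected change is a 1.2-fold higher number from compound 2 to compound 3 (0.09 log units; within the scatter), none beyond the scatter. Compound 3 is estimated at 30000 nM, within a range of 8000 nM to 60000 nM.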

Compound 3, half-maximal inhibitory concentration: 19200 nM
The estimate for compound 3 lay 1.6-fold (0.19 log units) above the measured number; the measured number falls inside the stated range.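

In this assay there is a 1.3-fold lower number from compound 2 to compound 3 (0.10 log units; within the scatter), so on this amide-type nitrogen in a ring, an aromatic 4-chlorophenyl and a small cyclopropyl cannot be told apart. For the compounds shown here, the new compound also gives the first step at this position that clears the scatter, an at least 2.0-fold lower number from compound 1 to compound 3 (0.31 log units; beyond the scatter), which shows that the two aryl groups are not interchangeable here. That step has only a floor for its size, set by a limit for compound 1: the limit of > 40000 nM in this assay, at which 1 of the 3 values shown sits.

From the compounds shown here alone, it remains open whether an amine, a carboxylic acid or a longer chain on this nitrogen would shift the number beyond the scatter.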